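This account rests on a few compounds, and the source may have more. Where it says the series, first, only, none or still open, it means among the compounds named here.

Compound 1 `N#CC1=C(N)Oc2c(c3nc4ccccc4nc3c3ccccc23)C12C(=O)N(Cc1cnnn1-c1ccccc1Br)c1ccccc12`: in a functional assay on HepG2 cells (Homo sapiens) for antiproliferative activity, read by MTT assay, with a stated time of 48 h (on this read-out higher numbers stand for weaker inhibition and lower numbers for stronger inhibition), compound 1 gives only a limit, > 50000 nM.
Compound 2 `N#CC1=C(N)Oc2c(N)cc3nc4ccccc4nc3c2C12C(=O)N(Cc1cnnn1-c1cccc(C(F)(F)F)c1)c1ccccc12`: in this assay compound 2 gives 15800 nM.

Compound 2 holds the only number shown in this assay. Compound 1 is the value sitting at the limit of > 50000 nM in this assay, at which 1 of the 2 values shown sits. Compound 3 `N#CC1=C(N)Oc2c(N)cc3nc4ccccc4nc3c2C12C(=O)N(Cc1cnnn1-c1ccc(Cl)cc1Cl)c1ccccc12` is not yet measured. Its change from compound 2 is 2,4-dichlorophenyl in place of 3-(trifluoromethyl)phenyl on an aromatic nitrogen. Going by the values given here, no step between measured compounds is available, so no direction can be read from the series; the expected step in this assay is none beyond the usual scatter. Compound 3 is estimated at 15000 nM, within 5000 nM to 50000 nM. The expected step is a 1.1-fold lower number from compound 2 to compound 3 (0.02 log units; within the scatter).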

Compound 3, half-maximal inhibitory concentration: > 50000 nM
Compound 3 ended at the assay's limit; the forecaster's own chance of this, stated with the estimate: 25%; middle value at least 3.3-fold (0.52 log units) from the limit.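

In this assay, going by these compounds alone, this aromatic nitrogen is the first position where a single change can be read: 2,4-dichlorophenyl in place of 3-(trifluoromethyl)phenyl gives an at least 3.1-fold higher number from compound 2 to compound 3 (0.50 log units; beyond the scatter). The aryl group here therefore affects the read-out, and the step is only a lower bound on the change. Compound 3 gives a limit, not a number, and joins the values sitting there: the limit of > 50000 nM in this assay, at which 2 of the 3 values shown sit.

The compounds shown leave open whether the loss follows the chlorine atoms, their places on the phenyl ring, or the departure of trifluoromethyl. A 3-chlorophenyl or an unsubstituted phenyl on this nitrogen would help separate these.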